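Replacing a fluoropyridinyl group with a triazolyl group in an amide

A few compounds are considered here, and "the series" means these few. Any claim that something is new, unique, unknown or untested is made for them only; others in the source may bear on it.

Compound 3 `Cc1ccc(-c2cc(C(=O)N[C@H](C)c3ccc(F)cn3)cc(-c3ncccc3F)c2)nc1` was tested in an ADME assay on a cell-free system (plasma, Rattus norvegicus) for protein binding, and gave 99.2%. Among the three compounds measured, compound 3 has the lowest unbound fraction. Compound 1 `Cc1ccc(-c2cc(C(=O)N[C@H](C)c3ccc(F)cn3)cc(-n3nccn3)c2)nc1` gave 97.4%, and the move to compound 3 shows a 3.3-fold lower unbound fraction from compound 1 to compound 3 (0.51 log units; beyond the scatter). Compound 2 `Cc1ccc(-c2cc(C(=O)N[C@H](C)c3ccc(C(F)(F)F)[n+]([O-])c3)cc(-c3ncccc3F)c2)nc1` gave 95.2%, and the move to compound 3 shows a 6.0-fold lower unbound fraction from compound 2 to compound 3 (0.78 log units; beyond the scatter).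

Compound 4 `Cc1ccc(-c2cc(C(=O)N[C@@H](C)c3nnc[nH]3)cc(-c3ncccc3F)c2)nc1` has not yet been measured. It differs from compound 3 in one place: 1-(4H-1,2,4-triazol-3-yl)ethyl in place of 1-(5-fluoropyridin-2-yl)ethyl on an amide-type nitrogen. In plain terms, the ring carrying the ethyl group on the amide-type nitrogen changes from a six-membered aromatic ring with one hetero atom to a five-membered aromatic ring with three hetero atoms, and the new group brings a hydrogen-bond donor.

Among the measured compounds shown here, no measured step matches this exact change. Still, the step from compound 1 to compound 3 shows that swapping a small triazolyl for a fluoropyridinyl lowered the unbound fraction, and the reverse kind of exchange here would be expected to raise it. The step from compound 2 to compound 3 likewise shows that the more polar partner had the higher unbound fraction. For compound 4 the expected step is therefore a 4.4-fold higher unbound fraction from compound 3 to compound 4 (0.64 log units; beyond the scatter), towards a higher unbound fraction. Compound 4 is estimated at 96.5%, with a range of 93% to 98.5%.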

Compound 4, plasma protein binding: 98.8%
Beside the measured number, compound 4's estimate is 2.9-fold (0.46 log units) (unbound fraction) above it; the measured number lies above the stated range.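

In this assay, replacing the ring on this ethyl group gives a 1.5-fold higher unbound fraction from compound 3 to compound 4 (0.18 log units; within the scatter), so 1-(4H-1,2,4-triazol-3-yl)ethyl and 1-(5-fluoropyridin-2-yl)ethyl on the amide-type nitrogen cannot be told apart in this read-out, even though the entering group has a five-membered aromatic ring with three hetero atoms and a hydrogen-bond donor. The earlier exchange at this position gave a 6.0-fold lower unbound fraction from compound 2 to compound 3 (0.78 log units; beyond the scatter), so this position can produce a step beyond the scatter, but the present change does not. Nothing measured here accounts for the difference between these two steps.

The compounds shown leave open whether a group of another kind at this position, such as a carboxylic acid or an amine in place of the aromatic ring, would separate itself from compound 3 beyond the scatter. They also leave open whether the same exchange on the amide-type nitrogen would give a similar step with 2H-1,2,3-triazol-2-yl in place of 3-fluoropyridin-2-yl elsewhere on the core.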